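The source may report more compounds than this note shows. Statements on the series, on what has been measured and on what is new or still open speak of the compounds shown alone.

Measured in a functional assay on DU-145 cells (Homo sapiens) for inhibition, read by trypan blue exclusion, with a stated time of 96 h; on this read-out higher numbers stand for weaker inhibition of growth and lower numbers for stronger inhibition of growth:
- compound 1 `COc1ccccc1/C=C(/SCc1ccc(Cl)c(Cl)c1)C(=O)c1ccc(Cl)cc1`: 10000 nM
- compound 2 `O=C(/C(=C\c1ccccc1OCc1ccccc1)SCc1ccc(F)cc1)c1ccc(Cl)cc1`: 1000 nM
- compound 3 `COc1ccccc1/C=C(/SCc1ccc(Cl)cc1)C(=O)c1ccc(Cl)cc1`: 1000 nM

Compound 3 stands level with compound 2, and both numbers are lower than that of compound 1. Compound 4 `COc1ccccc1/C=C(/SCc1ccc(F)cc1)C(=O)c1ccc(Cl)cc1` departs from compound 3 by one exchange, (fluoro in place of chloro on an aromatic carbon), which is fluoro in place of chloro on an aromatic carbon, para to a large group.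

Within the data shown here, only one measured step bears on this exchange. It is a 10-fold lower number from compound 1 to compound 3 (1.00 log units; beyond the scatter), a modest change that lies beyond the scatter, with hydrogen in place of chloro on an aromatic carbon. That step removes a halogen rather than swapping one, so it is only a loose guide. Among the measured compounds shown here, compound 2 already carries the 4-fluorobenzyl group and reads 1000 nM, but it differs from compound 4 at another group, so no direct step can be drawn from it. Even so, its value gives no sign of a shift in this assay, and no step beyond the scatter is expected in either direction. The estimated change is no change at the digits printed from compound 3 to compound 4 (within the scatter). Compound 4 is expected to read 1000 nM, with an estimated range from 300 nM to 4000 nM.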

Compound 4, concentration for 50% growth inhibition: 10000 nM
Compound 4: the middle estimate sits 10-fold (1.00 log units) below what was measured; measured number outside the range, above it.
By their numbers in this assay, from the lowest: compounds 2 and 3 (each within the scatter of the next); then compounds 1 and 4 (each within the scatter of the next).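

In this assay, the halogen on the benzyl group proves not to be interchangeable: fluoro in place of chloro on this aromatic carbon, para to a large group, gives a 10-fold higher number from compound 3 to compound 4 (1.00 log units; beyond the scatter). The 4-fluorobenzyl group does not by itself fix the level of growth inhibition, since the change from a benzyloxy to a methoxy group on the other aromatic ring, with that group held constant, gives a 10-fold higher number from compound 2 to compound 4 (1.00 log units; beyond the scatter). Among the three compounds that carry the methoxy group, the 4-chlorobenzyl group of compound 3 alone reaches the lower level, as 4-fluorophenyl in place of 3,4-dichlorophenyl gives no change at the digits printed from compound 1 to compound 4 (within the scatter).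

Nothing available here accounts for the gap between the chloro and fluoro compounds. As far as these compounds go, it remains open how a 4-bromobenzyl or unsubstituted benzyl group would read, and whether a benzyloxy group combined with the 4-chlorobenzyl group would give a lower number than either compound 2 or compound 3.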